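Nitro in Place of Bromo on a Shared Core

The source may hold more compounds than are shown below. What is called first, only, known or untested is meant among the compounds shown, and "the series" means these compounds.

The account follows three compounds built on one shared core. Compound 1 `CCn1c(/C=C2/C(=O)Nc3ccc(F)cc32)nc2ccccc21` carries a fluoro group, compound 2 `CCn1c(/C=C2/C(=O)Nc3ccc(Br)cc32)nc2ccccc21` a bromo group, and compound 3 `CCn1c(/C=C2/C(=O)Nc3ccc([N+](=O)[O-])cc32)nc2ccccc21` a nitro group on the same aromatic carbon. In a functional assay on PC-3 cells (Homo sapiens) for cytotoxicity, read by MTT assay, with a stated time of 48 h (on this read-out lower numbers stand for stronger inhibition and higher numbers for weaker inhibition), compound 1 gives only a limit, > 50000 nM. Compound 2 gives 42700 nM in this assay. The step of an at least 1.1-fold lower number from compound 1 to compound 2 (0.06 log units; that floor lies within the scatter) starts from that limit and stays within the scatter. For the measured compounds named here, compound 2 therefore stands on the only number reported; the other value shown is a limit, (the limit of > 50000 nM in this assay, at which 1 of the 2 values shown sits). Compound 3 differs from compound 2 by nitro in place of bromo on an aromatic carbon. Going by the values given here, the single measured step, from compound 1 to compound 2, exchanged one halogen for another, and no measured step involves a nitro group, so it bears on the new change only loosely. With that one step within the scatter, compound 3 is expected to give 40000 nM in this assay, with a range from 15000 nM to 100000 nM. This estimate means an expected step of a 1.1-fold lower number from compound 2 to compound 3 (0.03 log units; within the scatter), not beyond the scatter, in either direction.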

Compound 3, half-maximal inhibitory concentration: 40100 nM
Beside the measured number, compound 3's estimate is 1.0-fold (0.00 log units) below it; the range from low to high includes it.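

The nitro group brings 3 heavy atoms and 2 hydrogen-bond acceptors to the aromatic carbon where the bromo group brought 1 heavy atom and none, and in this assay the result is a 1.1-fold lower number from compound 2 to compound 3 (0.03 log units; within the scatter). The earlier compounds had shown only one halogen exchanged for another, so this is the first sign that a group other than a halogen can sit on this carbon without a change beyond the scatter. Against the fluoro group the comparison gives only a floor, an at least 1.2-fold lower number from compound 1 to compound 3 (0.09 log units; that floor lies within the scatter), and it starts from a value that is a limit and not a number: the limit of > 50000 nM in this assay, at which 1 of the 3 values shown sits.

Every step shown lies within the scatter or has a floor within it, so the compounds do not yet show any group at this position moving the number beyond the scatter. Going by these compounds, whether an amine or a carboxylic acid on this same aromatic carbon would do so stays open, as does the effect on the read-out of a change anywhere else on the shared core.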